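Cytotoxicity series: aryl amide variations, step to compound 4

The compounds below may be only part of what the source reports. "The series", "measured", "known", "first", "only" and "open" are said of these compounds alone.

Three amides sharing one core have been measured in an ADME assay on Raji cells (Homo sapiens) for cytotoxicity, read by CellTiter-Glo and resazurin assay, with a stated time of 72 h; on this read-out higher numbers stand for an effect only at larger amounts of compound and lower numbers for an effect already at smaller amounts. Compound 1 `CCOC(=O)CCCCCOc1cccc(CN(C(=O)c2ccc(-c3ccc4ccccc4c3)cc2)C(C)C)c1` carries a naphthalen-2-yl group; compound 2 `CCOC(=O)CCCCCOc1cccc(CN(C(=O)c2ccc(-c3cnc(OC)nc3OC)cc2)C(C)C)c1` a 2,4-dimethoxypyrimidin-5-yl group; compound 3 `CCOC(=O)CCCCCOc1cccc(CN(C(=O)c2ccc(-c3ccc(C(C)=O)s3)cc2)C(C)C)c1` a 5-acetylthiophen-2-yl group. In this assay compound 1 gives only a limit, > 26000 nM. Compound 2 likewise gives only a limit, > 26000 nM. Compound 3 too reaches only a limit, > 26000 nM. Hence a step that the two limits leave unreadable from compound 1 to compound 2, a step that the two limits leave unreadable from compound 1 to compound 3 and a step that the two limits leave unreadable from compound 2 to compound 3, as the limit of > 26000 nM in this assay, at which 3 of the 3 values shown sit, shows.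

Compound 4 `CCOC(=O)CCCCCOc1cccc(CN(C(=O)c2ccc(-c3cccc(Cl)c3)cc2)C(C)C)c1` differs from compound 3 by 3-chlorophenyl in place of 5-acetylthiophen-2-yl on an aromatic carbon. Among the measured compounds shown here, no measured step gives a readable size, so no step beyond the scatter is expected; compound 4 is estimated at 30000 nM (range 12000 nM to 100000 nM), that is an expected step that the limit leaves unreadable from compound 3 to compound 4, most likely again a limit.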

Compound 4, half-maximal effective concentration: > 18400 nM
Compound 4: no number, only a limit; the forecaster's own chance of this, stated with the estimate: 85%; the middle value lies beyond the limit too.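

Among the compounds shown here, compound 4, like compound 1, compound 2 and compound 3, gives only a limit in this assay, so no step among them can be read. The compounds shown leave open whether any group at this place gives a readable value.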